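Amide Substituent Change in Diaryl Ether Thioureas

The source may hold more compounds than are shown below. What is called first, only, known or untested is meant among the compounds shown, and "the series" means these compounds.

Measured compounds:
Compound 1, `CNC(=O)c1cc(Oc2cccc(NC(=S)Nc3ccc(Cl)cc3Cl)c2)ccn1`, 41200 nM in a functional assay on HCT-116 cells (Homo sapiens) for cytotoxicity, read by MTT assay, with a stated time of 48 h; on this read-out higher numbers stand for weaker inhibition and lower numbers for stronger inhibition.
Compound 2, `CNC(=O)c1cc(Oc2cccc(NC(=S)Nc3ccc(Cl)cc3)c2)ccn1`, 39400 nM in this assay.

Compound 2 and compound 1 sit within the scatter of each other in this assay, as the step of a 1.0-fold lower number from compound 1 to compound 2 (0.02 log units; within the scatter) shows; on the two numbers available, compound 2 cannot be set apart from compound 1. Compound 3, `CC(C)NC(=O)c1cc(Oc2cccc(NC(=S)Nc3ccc(Cl)cc3)c2)ccn1`, differs from compound 2 by isopropyl in place of methyl on an amide-type nitrogen. Among the measured compounds shown here, no measured step bears on this change: the only step recorded, from compound 1 to compound 2, alters a chloro on an aromatic carbon and leaves the amide-type nitrogen untouched, so nothing in the data speaks for a shift in this assay beyond the scatter. The expected step is a 1.0-fold lower number from compound 2 to compound 3 (0.00 log units; within the scatter). Compound 3 is estimated at 39000 nM in this assay, with a range from 15000 nM to 100000 nM.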

Compound 3, half-maximal inhibitory concentration: 22100 nM
Compound 3: the middle estimate sits 1.8-fold (0.25 log units) above what was measured, and the stated range covers the measured number.
By their numbers in this assay, from the lowest: compounds 3, 2 and 1 (each within the scatter of the next).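

Among the compounds shown here, compounds 1 and 2 differ only by a chloro on an aromatic carbon, so compound 3 gives the first reading at the amide-type nitrogen: in this assay, isopropyl in place of methyl gives a 1.8-fold lower number from compound 2 to compound 3 (0.25 log units; within the scatter), a step printed as within the scatter. Methylcarbamoyl and isopropylcarbamoyl therefore cannot be set apart in this assay, even though the substituent on this nitrogen grows from one heavy atom to three. No available evidence bears on this result.

Going by these compounds, whether a cyclohexyl or benzyl group, or a longer chain ending in an amine, on this nitrogen would move the number beyond the scatter remains open. On these data alone, it is also open whether hydrogen in place of methyl on this nitrogen would leave the number within the scatter of compound 2.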